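Chain Extension on a Core That Sits at the Limit

The source may hold more compounds than are shown below. What is called first, only, known or untested is meant among the compounds shown, and "the series" means these compounds.

Compound 1 `CCCc1cnc2c(C#N)c(N3CCN(c4ncccn4)CC3)ccn12`: in a functional assay on CHO cells with metabotropic glutamate receptor 2 (Homo sapiens) as the target, read by GTPgammaS binding (on this read-out higher numbers stand for an effect only at larger amounts of compound and lower numbers for an effect already at smaller amounts), compound 1 gives only a limit, > 3160 nM.
Compound 2 `CCc1cnc2c(C#N)c(N3CCN(c4nc(C)cc(C)n4)CC3)ccn12`: in this assay compound 2 gives 2290 nM.
Compound 3 `CCc1cnc2c(C#N)c(N3CCN(c4ncccn4)CC3)ccn12`: in this assay compound 3 gives only a limit, > 3160 nM.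

Compound 3 thus stands at the limit of > 3160 nM in this assay, at which 2 of the 3 values shown sit, and has no number of its own. Compound 4 `N#Cc1c(N2CCN(c3ncccn3)CC2)ccn2c(CCC3CC3)cnc12` differs from it by cyclopropyl in place of hydrogen on a saturated chain carbon, two bonds along the chain from an aromatic carbon. Within the data shown here, two measured steps bear on this change. The step that the two limits leave unreadable from compound 1 to compound 3 touches the same chain carbon, but it cannot be read, since both of its values are limits. The step of an at least 1.3-fold higher number from compound 2 to compound 3 (0.13 log units; that floor lies within the scatter) concerns a different part of the molecule and is small. On that basis no step beyond the scatter is expected for a step that the limit leaves unreadable from compound 3 to compound 4, and compound 4 is expected to give about 4500 nM, between 1500 nM and 14000 nM, most likely again only a limit.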

Compound 4, half-maximal effective concentration: 1100 nM
Estimate against measurement, compound 4: 4.1-fold (0.61 log units) above, outside the stated range (below it).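

In this assay, cyclopropyl at this saturated chain carbon gives an at least 2.8-fold lower number from compound 3 to compound 4 (0.45 log units; beyond the scatter), and set against methyl at the same carbon it gives an at least 2.8-fold lower number from compound 1 to compound 4 (0.45 log units; beyond the scatter). Among these compounds, this is the first sign that the chain on the shared core can move the read-out beyond the scatter. Both steps are floors and the step between the two shorter chains stays unreadable, as their compounds sit at a limit: the limit of > 3160 nM in this assay, at which 2 of the 4 values shown sit.

The compounds shown leave open whether the three-membered ring matters or a plain longer chain such as pentyl would serve equally. Also open, going by these compounds, is whether 2-cyclopropylethyl would combine with the 4,6-dimethylpyrimidin-2-yl group of compound 2.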